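The source may report more compounds than this note shows. Statements on the series, on what has been measured and on what is new or still open speak of the compounds shown alone.

Working notes on the series. In a functional assay on HL-60 cells (Homo sapiens) for inhibition, read by MTT assay, with a stated time of 72 h (on this read-out lower numbers stand for stronger inhibition and higher numbers for weaker inhibition), compound 3 (`COc1cc(-c2nc(C)oc2C(=O)N2CCN(c3cccc(Cl)c3)CC2)ccc1O`) gives 85.9 nM, and compound 2 (`Cc1nc(-c2ccccc2Cl)c(C(=O)N2CCN(c3cccc(Cl)c3)CC2)o1`) gives 132 nM, within the scatter of compound 3. Compound 1 (`CC(=O)Nc1cccc(-c2nc(C)oc2C(=O)N2CCN(c3cccc(Cl)c3)CC2)c1`) gives 208 nM. The only gap beyond the scatter is a 2.4-fold lower number from compound 1 to compound 3 (0.38 log units; beyond the scatter).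

Compound 4 (`Cc1nc(-c2ccccc2F)c(C(=O)N2CCN(c3cccc(Cl)c3)CC2)o1`) differs from compound 3 by 2-fluorophenyl in place of 4-hydroxy-3-methoxyphenyl on an aromatic carbon, with 2-fluorophenyl on the aromatic carbon next to the ring nitrogen. The bearing steps are small: a 1.5-fold lower number from compound 2 to compound 3 (0.19 log units; within the scatter) and a 1.6-fold lower number from compound 1 to compound 2 (0.20 log units; within the scatter), both within the scatter. Compound 2, with its 2-chlorophenyl group, is the nearest measured compound at 132 nM. The expected move in this assay is therefore slight and upward, not clearly beyond the scatter: a 1.6-fold higher number from compound 3 to compound 4 (0.21 log units; within the scatter). For compound 4 the estimated value is 140 nM, with an expected range of 60 nM to 320 nM.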

Compound 4, half-maximal inhibitory concentration: 39.4 nM
The estimate for compound 4 lay 3.6-fold (0.55 log units) above the measured number; measured number below the stated range.
By their numbers in this assay, from the lowest: compound 4; then compounds 3, 2 and 1 (each within the scatter of the next, the first and the last beyond it).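

In this assay, going by these compounds alone, fluoro in place of chloro on the phenyl group gives a 3.4-fold lower number from compound 2 to compound 4 (0.53 log units; beyond the scatter), showing that this position responds to a single halogen swap. 2-Fluorophenyl also stands beyond the scatter against the two larger groups, with a 2.2-fold lower number from compound 3 to compound 4 (0.34 log units; beyond the scatter) and a 5.3-fold lower number from compound 1 to compound 4 (0.72 log units; beyond the scatter), whereas only one step among the earlier compounds passed the scatter. No available evidence bears on what lies behind these steps.

On these data alone, whether 2-methylphenyl or 2-aminophenyl at this position would match 2-fluorophenyl remains open. So does whether an unsubstituted phenyl group would fall with the halogen-bearing groups.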